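Compound 3: 3,5-Difluorophenyl in Place of 3-Chlorophenyl

The source may hold more compounds than are shown below. What is called first, only, known or untested is meant among the compounds shown, and "the series" means these compounds.

Among the compounds with values here, compound 2 `C=C/C=C\[C@H](C)[C@H](OC(N)=O)[C@@H](C)[C@H](O)[C@@H](C)C/C(C)=C\[C@H](C)[C@@H](O)[C@@H](C)/C=C\CCc1cccc(Cl)c1` holds the lower of the two numbers measured so far. In a functional assay on SK-OV-3 cells (Homo sapiens) for cytotoxicity (on this read-out lower numbers stand for stronger inhibition and higher numbers for weaker inhibition), compound 2 gives 380 nM, whereas compound 1 `C=C/C=C\[C@H](C)[C@H](OC(N)=O)[C@@H](C)[C@H](O)[C@@H](C)C/C(C)=C\[C@H](C)[C@@H](O)[C@@H](C)/C=C\CCc1ccc(C)c(F)c1` gives 1000 nM. Compound 3 `C=C/C=C\[C@H](C)[C@H](OC(N)=O)[C@@H](C)[C@H](O)[C@@H](C)C/C(C)=C\[C@H](C)[C@@H](O)[C@@H](C)/C=C\CCc1cc(F)cc(F)c1` keeps the shared core and differs from compound 2 only at the aromatic end of the chain (3,5-difluorophenyl in place of 3-chlorophenyl on a saturated chain carbon, two bonds along the chain from a double-bonded chain carbon). It carries 3,5-difluorophenyl in place of 3-chlorophenyl on a saturated chain carbon, two bonds along the chain from a double-bonded chain carbon.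

Within the data shown here, only one measured step bears on this change. It is a 2.6-fold lower number from compound 1 to compound 2 (0.42 log units; beyond the scatter), a modest step beyond the scatter, made at the same place. Like compound 1 at 1000 nM, compound 3 has fluorine on the aromatic ring and no chlorine, so a small move back towards higher numbers in this assay is expected, no larger than that step. A single pair cannot settle the direction, and the move may stay within the scatter. The expected step is a 1.6-fold higher number from compound 2 to compound 3 (0.20 log units; within the scatter). Compound 3 is estimated at 600 nM, with an expected range of 220 nM to 1500 nM.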

Compound 3, half-maximal inhibitory concentration: 360 nM
Compound 3: middle estimate off by 1.7-fold (0.22 log units), on the high side; the measured number falls inside the stated range.
By their numbers in this assay, from the lowest: compounds 3 and 2 (each within the scatter of the next); then compound 1.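

In this assay the exchange of 3-chlorophenyl for 3,5-difluorophenyl gives a 1.1-fold lower number from compound 2 to compound 3 (0.02 log units; within the scatter) at this place, so the ring at the end of the chain can lose its chlorine and carry two fluorines with no change that can be told from the scatter. Compound 1 also has fluorine and no chlorine, yet the step of a 2.8-fold lower number from compound 1 to compound 3 (0.44 log units; beyond the scatter) sets it apart from compound 3, just as a 2.6-fold lower number from compound 1 to compound 2 (0.42 log units; beyond the scatter) sets it apart from compound 2, so the presence of fluorine alone does not go with the higher number of compound 1. Among these three compounds, the higher number stays with the one ring that carries a methyl group, 3-fluoro-4-methylphenyl, and compounds 2 and 3 cannot be ordered. No measurement beyond these cytotoxicity numbers is available to explain this pattern.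

With only three rings compared, the compounds shown do not separate the part played by the methyl group from that of the pattern of halogens around the ring. They also leave open how an unsubstituted phenyl ring, a ring bearing an amine or a carboxylic acid, or a longer chain leading to the ring would fare in this assay at this place.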